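The compounds below may be only part of what the source reports. "The series", "measured", "known", "first", "only" and "open" are said of these compounds alone.

The study sets two measured compounds side by side before turning to an untested one. Compound 1, `CCONC(=O)c1sc(N2N=C(c3ccc(C)cc3)CC2c2cc3cc(OC)ccc3nc2Cl)nc1C`, is evaluated in a functional assay on DLD-1 cells (Homo sapiens) for antiproliferative activity (on this read-out lower numbers stand for stronger inhibition and higher numbers for weaker inhibition), where compound 1 gives 38 nM. Compound 2, `COc1ccc2nc(O)c(/C=C/C(=O)c3ccc(C)cc3)cc2c1`, is built on the same quinoline-bearing scaffold but carries an open chain instead of the five-membered non-aromatic ring; in this assay compound 2 gives 38 nM. On the numbers shown, compound 1 stands level with compound 2 at the digits reported, the two values falling within the usual scatter of each other, so no order can be drawn between them.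

Compound 3, `COc1ccc2nc(Cl)c(C3CC(c4ccc(C)cc4)=NN3c3nc(-c4ccc(C)cc4)cs3)cc2c1`, has not yet been measured in this assay. It differs from compound 1 in a single place: 4-(4-methylphenyl)-1,3-thiazol-2-yl in place of 5-(ethoxycarbamoyl)-4-methyl-1,3-thiazol-2-yl on an amine nitrogen in a ring. The group that leaves carries one hydrogen-bond donor and four acceptors; the group that enters carries none and two, and brings a six-membered aromatic ring of carbon only in place of the ethoxycarbamoyl and methyl substituents.

Among the compounds with values here, no measured pair shows what such an exchange does. The author therefore expects a step from compound 1 to compound 3 of a 1.3-fold higher number from compound 1 to compound 3 (0.12 log units; within the scatter), which may fall within the scatter. For compound 3 the estimate in this assay is 50 nM, with a range from 15 nM to 200 nM.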

Compound 3, half-maximal inhibitory concentration: 38 nM
For compound 3 the middle estimate is 1.3-fold (0.12 log units) above the measured one; the range from low to high includes it.
By their numbers in this assay, from the lowest: compounds 1, 2 and 3 (each within the scatter of the next).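

In this assay, within the data shown here, putting 4-(4-methylphenyl)-1,3-thiazol-2-yl in place of 5-(ethoxycarbamoyl)-4-methyl-1,3-thiazol-2-yl on the amine nitrogen in the ring gives no change at the digits printed from compound 1 to compound 3 (within the scatter), and this is the first step that can be read at this position. In this one pair, the hydrogen-bond donor of the leaving group is absent from the entering group, and a six-membered aromatic ring of carbon only stands where the ethoxycarbamoyl and methyl substituents stood, yet the read-out shows no separation, so neither that donor nor those two substituents are required here for a value at this level. No measurement given here bears on why the two groups read alike.

The ethoxycarbamoyl and methyl substituents left together while the 4-methylphenyl group arrived, so the compounds shown do not separate what each of these parts contributes. From the compounds shown here alone, it also remains open whether the same level would hold with a carboxylic acid or an amine on the 1,3-thiazol-2-yl ring, or with a plain phenyl group in place of the 4-methylphenyl group.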